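The source may hold more compounds than are shown below. What is called first, only, known or untested is meant among the compounds shown, and "the series" means these compounds.

Of the compounds shown here, three on one shared core have been measured so far. In a functional assay on PANC-1 cells (Homo sapiens) for inhibition, read by MTT assay, with a stated time of 24 h (a higher number here means a weaker inhibitor, a lower number a stronger inhibitor), compound 1 `CC1(C)[C@H]2CC[C@]1(C)N(Cc1cn(-c3ccc(C#N)cc3)nn1)C(=O)C2` reads 250 nM and compound 2 `CC1(C)[C@H]2CC[C@]1(C)N(Cc1cn(-c3ccccc3C#N)nn1)C(=O)C2` reads 240 nM with a cyanophenyl group in each. Compound 3 `CC1(C)[C@H]2CC[C@]1(C)N(Cc1cn(-c3ccc(O)cc3)nn1)C(=O)C2` carries 4-hydroxyphenyl and reads 100 nM (the lowest number of the three, which makes it the strongest inhibitor here). Moving the cyano group gives a 1.0-fold lower number from compound 1 to compound 2 (0.02 log units; within the scatter) and so no real change. Hydroxy in place of cyano gives a 2.5-fold lower number from compound 1 to compound 3 (0.40 log units; beyond the scatter) and 4-hydroxyphenyl in place of 2-cyanophenyl gives a 2.4-fold lower number from compound 2 to compound 3 (0.38 log units; beyond the scatter) which are both modest steps.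

Compound 4 `CC1(C)[C@H]2CC[C@]1(C)N(Cc1cn(-c3ccc(Cl)cc3)nn1)C(=O)C2` brings chloro in place of hydroxy on an aromatic carbon, para to a large group: chloro in place of hydroxy on an aromatic carbon describes the swap. For the measured compounds named here, no chloro compound has been measured yet, so the only guide is that both compounds lacking hydroxy gave higher numbers than compound 3 does. Going by the values given here, a modest rise in this assay is therefore expected, probably no larger than those steps. The estimated step is a 1.7-fold higher number from compound 3 to compound 4 (0.23 log units; within the scatter) toward a weaker inhibitor. Compound 4 is estimated at 170 nM with 70 nM to 400 nM as the expected range.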

Compound 4, half-maximal inhibitory concentration: 440 nM
Compound 4: the middle estimate sits 2.6-fold (0.41 log units) below what was measured; the whole stated range lies below it.
By their numbers in this assay, from the lowest: compound 3; then compounds 2, 1 and 4 (each within the scatter of the next).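

Read in this assay the change from 4-hydroxyphenyl to 4-chlorophenyl also gives a weaker inhibitor (a 4.4-fold higher number from compound 3 to compound 4 (0.64 log units; beyond the scatter)), so a third group in place of hydroxy, on an aromatic carbon para to a large group, has now given a higher number. Chloro does not separate from the two nitrile compounds, with both steps inside the scatter (a 1.8-fold higher number from compound 1 to compound 4 (0.25 log units; within the scatter); a 1.8-fold higher number from compound 2 to compound 4 (0.26 log units; within the scatter)), so compound 3 alone stands apart among these four, while compound 1, compound 2 and compound 4 cannot be ranked. No evidence is available to explain this difference.

Still open, from the compounds shown here alone, is whether a methoxy group or an amine in the same place would match hydroxy or fall with chloro and nitrile. The effect of moving hydroxy elsewhere on the ring is also unresolved.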